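From a Dichlorophenyl Ring to a Cyclohexyl Ring

This account rests on a few compounds, and the source may have more. Where it says the series, first, only, none or still open, it means among the compounds named here.

Of the compounds shown here, two with a shared core have been measured. Compound 1 `CC(C)(N)C(=O)N[C@H](COCc1cc(Cl)cc(Cl)c1)c1nnnn1CCOC(=O)NCCCCO` carries a 3,5-dichlorophenyl group; compound 2 `CC(C)(N)C(=O)N[C@H](COCc1cc(C(F)(F)F)cc(C(F)(F)F)c1)c1nnnn1CCOC(=O)NCCCCO` carries bis(trifluoromethyl)phenyl in its place. In a functional assay on cells for inhibition of growth hormone secretagogue receptor type 1 (Homo sapiens), read by FLIPR and calcium flux (on this read-out higher numbers stand for an effect only at larger amounts of compound and lower numbers for an effect already at smaller amounts), compound 1 gives 6.75 nM, the lowest of the two numbers, while compound 2 gives 34 nM, a gap that lies beyond the usual scatter.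

Compound 3 `CC(C)(N)C(=O)N[C@H](COCC1CCCCC1)c1nnnn1CCOC(=O)NCCCCO` has not been measured. It differs from compound 1 by a single exchange: cyclohexyl in place of 3,5-dichlorophenyl on a saturated chain carbon bound to an oxygen on a saturated carbon. The aromatic ring with its two chlorine atoms gives way to a saturated six-membered carbon ring.

Nothing measured shows directly what such an exchange does here. Given that compound 1 holds the best number, a weakening is expected, of moderate size, with the step of a 6.7-fold higher number from compound 1 to compound 3 (0.82 log units; beyond the scatter) taking compound 3 in this assay to an estimated 45 nM, in the range 10 nM to 250 nM.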

Compound 3, half-maximal effective concentration: 1.66 nM
Beside the measured number, compound 3's estimate is 27-fold (1.43 log units) above it; measured number outside the range, below it.
By their numbers in this assay, from the lowest: compound 3; then compound 1; then compound 2.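

In this assay, putting cyclohexyl in place of 3,5-dichlorophenyl gives a 4.1-fold lower number from compound 1 to compound 3 (0.61 log units; beyond the scatter), so at this position neither an aromatic ring nor chlorine atoms are required for a low number. The earlier compounds shown here both carried a substituted aromatic ring here and could not show this; now a saturated six-membered carbon ring without substituents gives the lowest number of the three. Nothing available explains why this exchange lowers the number.

On these data alone, it remains open whether a ring is needed at all, which a straight butyl chain or a smaller cyclopentyl ring in the same place would help to settle. As far as these compounds go, it is also open whether the exchange would give a similar step on a core changed elsewhere, for example with a carboxylic acid in place of the alcohol.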